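This account rests on a few compounds, and the source may have more. Where it says the series, first, only, none or still open, it means among the compounds named here.

In a functional assay on A549 cells (Homo sapiens) for inhibition, read by sulforhodamine B assay, with a stated time of 72 h (on this read-out lower numbers stand for stronger inhibition and higher numbers for weaker inhibition), compound 1 `Nc1sc(-c2ccc(Cl)cc2)c(-c2ccc(Cl)cc2)c1C(=O)NC1CCC(O)CC1` gives 250 nM, while compound 2 `CC(C)(C)NC(=O)c1c(N)sc(-c2ccc(Cl)cc2)c1-c1ccc(Cl)cc1` gives 8850 nM, the higher of the two numbers. Compound 3 `CN1CCN(C(=O)c2c(N)sc(-c3ccc(Cl)cc3)c2-c2ccc(Cl)cc2)CC1` alters the same amide group of compound 2: 4-methylpiperazin-1-yl in place of (tert-butyl)amino on a carbonyl carbon. For the measured compounds named here, one measured step bears on this change, a 35-fold higher number from compound 1 to compound 2 (1.55 log units; beyond the scatter). That large step shows that swapping the group on this amide can move the number a long way, although it involves a different new group. With compound 2 at the high end, a moderate move to a lower number is expected, and the expected change is a 3.0-fold lower number from compound 2 to compound 3 (0.47 log units; beyond the scatter). For compound 3, the estimated value is 3000 nM, within a range of 500 nM to 15000 nM.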

Compound 3, half-maximal inhibitory concentration: 590 nM
For compound 3 the middle estimate is 5.1-fold (0.71 log units) above the measured one, within the range that was stated.
By their numbers in this assay, from the lowest: compound 1; then compound 3; then compound 2.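

In this assay, 4-methylpiperazin-1-yl in place of (tert-butyl)amino gives a 15-fold lower number from compound 2 to compound 3 (1.18 log units; beyond the scatter), so a group without a hydrogen-bond donor on this carbonyl carbon can still give a low number. Compound 1 remains lowest, with 4-methylpiperazin-1-yl in place of (4-hydroxycyclohexyl)amino giving a 2.4-fold higher number from compound 1 to compound 3 (0.37 log units; beyond the scatter). No measurement given here explains these differences. Still open, going by these compounds, is whether a morpholin-4-yl or piperidin-1-yl group on this carbonyl carbon would give a number like that of compound 3, which would show how much the second ring nitrogen and its methyl matter.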